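The source may report more compounds than this note shows. Statements on the series, on what has been measured and on what is new or still open speak of the compounds shown alone.

Of the compounds shown here, three sharing one core have been measured in an assay for inhibition of Fatty-acid amide hydrolase 1 (Rattus norvegicus), using a Dixon plot; on this read-out lower numbers stand for stronger inhibition and higher numbers for weaker inhibition. Compound 1 `CSC(=O)CCCCc1cnc(C(=O)CCCCCCc2ccccc2)o1` gives 1.8 nM. Compound 2 `O=C(CCCCCCc1ccccc1)c1ncc(CCCCCO)o1` gives 10.1 nM. Compound 3 `O=C(CCCCCCc1ccccc1)c1ncc(CCCCCBr)o1` gives 6.1 nM, the second highest of the three numbers, with compound 2 nearest and within the scatter and compound 1 furthest and beyond it. Compound 4 `CSCCCCCc1cnc(C(=O)CCCCCCc2ccccc2)o1` differs from compound 3 by methylsulfanyl in place of bromo on a saturated chain carbon, five bonds along the chain from an aromatic carbon. Among the measured compounds shown here, two measured steps bear on this change: a 1.7-fold lower number from compound 2 to compound 3 (0.22 log units; within the scatter), and a 3.4-fold higher number from compound 1 to compound 3 (0.53 log units; beyond the scatter). The first lies within the scatter, while the second shows that a sulfur-bearing end group on the chain gave a lower number. A small step toward a lower number, a 1.5-fold lower number from compound 3 to compound 4 (0.18 log units; within the scatter), is therefore expected, near the edge of the scatter. Compound 4 is expected to give 4 nM, estimated between 1.5 nM and 12 nM.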

Compound 4, inhibition constant: 8.1 nM
The estimate for compound 4 lay 2.0-fold (0.31 log units) below the measured number; the range from low to high includes it.
By their numbers in this assay, from the lowest: compound 1; then compounds 3, 4 and 2 (each within the scatter of the next).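

In this assay, methylsulfanyl, bromo and hydroxy at the end of the chain cannot be told apart, with a 1.3-fold higher number from compound 3 to compound 4 (0.12 log units; within the scatter) and a 1.2-fold lower number from compound 2 to compound 4 (0.10 log units; within the scatter). Sulfur alone therefore does not set compound 1 apart: with a 4.5-fold higher number from compound 1 to compound 4 (0.65 log units; beyond the scatter), the change that counts here is the loss of the carbonyl from its (methylsulfanyl)carbonyl group. No measurement shown explains this. Going by these compounds, it remains open whether a methyl ester, a carboxylic acid or an amide at the chain end would match compound 1. On these data alone, a longer chain carrying the (methylsulfanyl)carbonyl group also remains open.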